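Isobutyl to benzyl: a small step expected

The compounds below may be only part of what the source reports. "The series", "measured", "known", "first", "only" and "open" are said of these compounds alone.

Measured in a functional assay on RS4-11 cells (Homo sapiens) for antiproliferative activity, read by MTT assay, with a stated time of 48 h; a lower number here means that less compound is needed, a higher number that more compound is needed for the effect:
- Compound 1 `COC(=O)c1[nH]c2cc(OC)ccc2c1C` gives > 100000 nM, which is a limit of the assay, not a number.
- Compound 2 `COC(=O)c1[nH]c2cc(OC)ccc2c1C(C)C` gives 81500 nM
- Compound 3 `COC(=O)c1[nH]c2cc(OC)ccc2c1CC(C)C` gives 37800 nM

Compound 3 has the lowest of the two true numbers, though it is still a high one. Compound 4 `COC(=O)c1[nH]c2cc(OC)ccc2c1Cc1ccccc1` carries phenyl in place of isopropyl on a saturated chain carbon bound to an aromatic carbon. Going by the values given here, two measured steps bear on this. The first is a 2.2-fold lower number from compound 2 to compound 3 (0.33 log units; beyond the scatter). The second is an at least 2.6-fold lower number from compound 1 to compound 3 (0.42 log units; beyond the scatter), and it starts from a limit. Neither brings in phenyl, so they guide only loosely. Resting on a 2.2-fold lower number from compound 2 to compound 3 (0.33 log units; beyond the scatter), the estimated change is small, perhaps nothing beyond the scatter: a 1.4-fold lower number from compound 3 to compound 4 (0.13 log units; within the scatter). The expected value for compound 4 is 28000 nM, with an estimated range from 10000 nM to 80000 nM.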

Compound 4, half-maximal effective concentration: 61600 nM
Estimate against measurement, compound 4: 2.2-fold (0.34 log units) below; low and high end bracket the measured number.
By their numbers in this assay, from the lowest: compounds 3, 4 and 2 (each within the scatter of the next, the first and the last beyond it). At a limit, above all of these: compound 1.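

Putting an aromatic ring at this position, with phenyl in place of isopropyl on a saturated chain carbon bound to an aromatic carbon, gives a 1.6-fold higher number from compound 3 to compound 4 (0.21 log units; within the scatter). The swap from isopropyl to benzyl likewise gives a 1.3-fold lower number from compound 2 to compound 4 (0.12 log units; within the scatter), so in this assay the ring brings no clear gain over either alkyl group. Compound 1 gives only a limit, so the step to benzyl, an at least 1.6-fold lower number from compound 1 to compound 4 (0.21 log units; that floor lies within the scatter), is a floor and not a true size: the limit of > 100000 nM in this assay, at which 1 of the 4 values shown sits.

From the compounds shown here alone, whether an amine or a carboxylic acid on the phenyl ring, or a longer chain such as hexyl, would lower the number at this position stays open.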